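The source may report more compounds than this note shows. Statements on the series, on what has been measured and on what is new or still open speak of the compounds shown alone.

Compound 2 `COC(=O)c1cc(=O)c2cc(NC(=O)Nc3ccc(Cl)c(Cl)c3)ccc2[nH]1`, compound 3 `COC(=O)c1cc(=O)c2cc(NC(=O)Nc3cccc(C(C)=O)c3)ccc2[nH]1` and the as yet unmeasured compound 4 `COC(=O)c1cc(=O)c2cc(NC(=O)Nc3ccc4c(c3)CCC4)ccc2[nH]1` share one core, while compound 1 `COc1ccc(-c2cc(=O)c3c(OC)cc(OC)cc3n2Cc2ccccc2)cc1` is built on another. In an ADME assay on BJ cells (Homo sapiens) for antiproliferative activity, with a stated time of 72 h (on this read-out lower numbers stand for an effect already at smaller amounts and higher numbers for an effect only at larger amounts of compound), compound 1 reaches only a limit of the assay, > 34400 nM. Compound 2 also reaches only a limit in this assay, > 12600 nM. Compound 3 likewise gives a limit in this assay, > 16000 nM. Every value shown is thus a limit (the limit of > 12600 nM in this assay, at which 1 of the 3 values shown sits, (the limit of > 16000 nM in this assay, at which 1 of the 3 values shown sits), (the limit of > 34400 nM in this assay, at which 1 of the 3 values shown sits)), and compound 3 stands among them without a number of its own. Going by the values given here, the single step between measured compounds, a step that the two limits leave unreadable from compound 2 to compound 3, cannot be read, both of its ends being limits.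

Compound 4 differs from compound 3 in one place: 2,3-dihydro-1H-inden-5-yl in place of 3-acetylphenyl on an amide-type nitrogen. Among the compounds with values here, no measured step bears on this change, and the one step available is unreadable, so there is nothing from which a direction or a size could be taken. The expectation for compound 4 therefore rests on the limits alone, and no shift beyond the scatter is expected. Compound 4 is estimated to give 20000 nM in this assay, with a range from 8000 nM to 50000 nM. This estimate means a step that the limit leaves unreadable from compound 3 to compound 4, and a limit rather than a number is expected to be the likely outcome.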

Compound 4, half-maximal effective concentration: > 24100 nM
Compound 4: only a limit was reported; the forecaster's own chance of this, stated with the estimate: 85%; middle value at least 1.2-fold (0.08 log units) away from the limit.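

Compound 4 also gives only a limit, so neither the step from compound 3 to compound 4 nor the step from compound 2 to compound 4 can be read, since both ends of each are limits. The compounds shown leave open at what concentration any of them takes effect in this assay, and whether the group on the amide-type nitrogen matters.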